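This account rests on a few compounds, and the source may have more. Where it says the series, first, only, none or still open, it means among the compounds named here.

Compound 1 `Cc1nc(Nc2ccccc2)sc1C(=O)/C=C/c1ccccc1` gives in a functional assay on NCI-H460 cells (Homo sapiens) for cytotoxicity, read by MTT assay (on this read-out lower numbers stand for stronger inhibition and higher numbers for weaker inhibition), only a limit, > 25000 nM. Compound 2 `Cc1nc(Nc2ccccc2)sc1C(=O)/C=C/c1ccccc1Cl` likewise gives only a limit in this assay, > 25000 nM. Both values sit at the limit of > 25000 nM in this assay, at which 2 of the 2 values shown sit, so the step that the two limits leave unreadable from compound 1 to compound 2 cannot be read. Compound 3 `Cc1nc(Nc2ccc(Cl)cc2)sc1C(=O)/C=C/c1ccccc1` differs from compound 1 by chloro in place of hydrogen on an aromatic carbon. For the measured compounds named here, the only measured step bearing on this change is the one from compound 1 to compound 2, and the two limits leave its size unreadable, so no comparison carries a usable size. For compound 3 in this assay the expected step that the limit leaves unreadable from compound 1 to compound 3 is therefore none beyond the scatter, with the value expected to reach only the limit again. The estimate for compound 3 is 40000 nM, between 15000 nM and 120000 nM.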

Compound 3, half-maximal inhibitory concentration: > 25000 nM
Compound 3: no number, only a limit; the forecaster's own chance of this, stated with the estimate: 85%; the middle value is on the limit's open side.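

No new step can be read between compound 1 and compound 3, since both give only a limit: the limit of > 25000 nM in this assay, at which 3 of the 3 values shown sit.

The compounds shown leave open whether any change to the shared core brings a readable value in this assay.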